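The compounds below may be only part of what the source reports. "The series", "measured", "known", "first", "only" and "open" are said of these compounds alone.

Measured so far in a functional assay, with a stated time of 30 min; on this read-out lower numbers stand for stronger inhibition and higher numbers for weaker inhibition:

Compound 1 `CCCCCCCCCCCCCCOc1cc(OC)c(Br)cc1C(C)=O` gives 16100000 nM
Compound 2 `CCCCCCCCCCCCCCCCOc1cc(OC)c(Br)cc1C(C)=O` gives 6500000 nM

Compound 2 holds the lower of the two numbers (6500000 nM). Among the compounds with values here, the one measured step (a 2.5-fold lower number from compound 1 to compound 2 (0.39 log units; beyond the scatter)) changed only the saturated chain and was modest. Compound 3 `CCCCCCCCCCCCCCCCOc1cc(OC)ccc1C(C)=O` keeps the chain of compound 2 and changes the ring instead (hydrogen in place of bromo on an aromatic carbon): hydrogen in place of bromo on an aromatic carbon. Within the data shown here, no measured pair shows what this swap does, so the chain step (a 2.5-fold lower number from compound 1 to compound 2 (0.39 log units; beyond the scatter)) serves only as a rough guide to size. A step of similar modest size is therefore expected in this assay, leaning towards a higher number, although the data leave the direction open. The step expected here is a 1.4-fold higher number from compound 2 to compound 3 (0.14 log units; within the scatter) as a rough estimate. For compound 3 the estimated value is 9000000 nM with an expected span from 3000000 nM to 27000000 nM around it.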

Compound 3, half-maximal inhibitory concentration: 39400000 nM
Beside the measured number, compound 3's estimate is 4.4-fold (0.64 log units) below it; the whole stated range lies below it.
By their numbers in this assay, from the lowest: compound 2; then compound 1; then compound 3.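

In this assay, replacing the bromo with hydrogen on this aromatic carbon gives a 6.1-fold higher number from compound 2 to compound 3 (0.78 log units; beyond the scatter), so this position on the ring affects the read-out, and compound 2, which carries the bromo, has the stronger inhibition. Within the data shown here, until this point, the only measured change was in the saturated chain, with a 2.5-fold lower number from compound 1 to compound 2 (0.39 log units; beyond the scatter); this step gives the first reading from the ring, and it too lies beyond the usual scatter. Nothing available explains why the bromo and hydrogen differ in this way.

From the compounds shown here alone, only bromo and hydrogen can be compared at this position, so it remains open how a chloro group or an amine would behave there. It is also unknown whether removing the bromo would have a similar effect on the shorter chain of compound 1.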